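Lengthening the Side Chain on a Shared Core

The source may report more compounds than this note shows. Statements on the series, on what has been measured and on what is new or still open speak of the compounds shown alone.

compound 1 `COc1ccc(-c2c(C)[nH]c(=O)n2C2CCCCC2)cc1`: 20400 nM
compound 2 `CCCCCOc1ccc(-c2c(C)[nH]c(=O)n2C2CCCCC2)cc1`: 9100 nM

Both compounds were tested in a functional assay on brain (Rattus norvegicus, strain Wistar) for inhibition; a lower number here means a stronger inhibitor, a higher number a weaker inhibitor. Among the compounds with values here, compound 2 stands with the lower of the two numbers; the only measured step is a 2.2-fold lower number from compound 1 to compound 2 (0.35 log units; beyond the scatter), a modest gain from growing the chain. Compound 3 `CCCCCCCCc1ccc(-c2c(C)[nH]c(=O)n2C2CCCCC2)cc1` has not been measured yet; it differs from compound 2 by octyl in place of pentyloxy on an aromatic carbon. That single step is all that bears on this change, so a further lengthening of the chain is expected to bring a similar modest step, a 1.8-fold lower number from compound 2 to compound 3 (0.26 log units; within the scatter). Compound 3 is therefore estimated at 5000 nM, within a range from 2000 nM to 15000 nM.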

Compound 3, half-maximal inhibitory concentration: 10300 nM
For compound 3 the middle estimate is 2.1-fold (0.31 log units) below the measured one; the measured number falls inside the stated range.
By their numbers in this assay, from the lowest: compounds 2, 3 and 1 (each within the scatter of the next, the first and the last beyond it).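

Replacing pentyloxy with octyl on this aromatic carbon removes the oxygen and lengthens the chain, yet gives a 1.1-fold higher number from compound 2 to compound 3 (0.05 log units; within the scatter) in this assay, so the two chains cannot be told apart here. Octyl in place of methoxy gives a 2.0-fold lower number from compound 1 to compound 3 (0.30 log units; within the scatter) and so also stays inside the usual scatter. Nothing available explains these results. Still open, going by these compounds, is whether a longer chain such as dodecyl, or an amine at the end of the octyl chain, would shift the number beyond the scatter.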